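Acetamido in place of (butylcarbonyl)oxy on the shared core

The source may hold more compounds than are shown below. What is called first, only, known or untested is meant among the compounds shown, and "the series" means these compounds.

Working notes on two measured compounds and one awaiting measurement. In a functional assay on HT-1080 cells (Homo sapiens), read by transwell migration, with a stated time of 24 h, tested at 10 uM (a higher number here means a weaker effect of the compound at the concentration tested, a lower number a stronger effect), compound 1 `CCCCC(=O)OCc1ccc2oc(=O)c(C(=O)Oc3cccc(Br)c3)cc2c1` gives 32.3%, the lowest of the two numbers available. Compound 2 `O=C(Oc1cccc(Cl)c1)c1cc2cc(CCl)ccc2oc1=O` gives 67% in this assay, a number that stands well beyond the scatter above that of compound 1. For the measured compounds named here, no pair differing in a single place has been measured, so the two values show only that the compounds differ, not what any one change does.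

Compound 3 `CC(=O)NCc1ccc2oc(=O)c(C(=O)Oc3cccc(Br)c3)cc2c1` differs from compound 1 in one place: acetamido in place of (butylcarbonyl)oxy on a saturated chain carbon bound to an aromatic carbon. Going by the values given here, with no measured step to lean on, the expected step from compound 1 to compound 3 in this assay is a number 12.7 percentage points higher from compound 1 to compound 3 (beyond the scatter), a modest weakening, though a result within the scatter would not surprise. Compound 3 is thus estimated at 45% in this assay, within a range from 25% to 70%.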

Compound 3, a percentage reported as activity, at one concentration (the size of the read-out at that concentration, not a potency): 27.1%
Compound 3: the middle estimate sits 17.9 percentage points above what was measured; the measured number falls inside the stated range.
By their numbers in this assay, from the lowest: compounds 3 and 1 (each within the scatter of the next); then compound 2.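

For the compounds shown here, the exchange of acetamido for (butylcarbonyl)oxy on a saturated chain carbon bound to an aromatic carbon gives the first single-place comparison: in this assay, it yields a number 5.2 percentage points lower from compound 1 to compound 3 (within the scatter). This position on the shared core therefore carries either group with no difference that can be read in this assay, although the group that enters has 4 heavy atoms and 1 hydrogen-bond donor, and the group that leaves has 7 heavy atoms and 0 hydrogen-bond donors. Nothing available accounts for this result.

As far as these compounds go, whether an amine or a carboxylic acid at this same place would also leave the read-out within the scatter remains open. Compound 2 differs from compound 1 and compound 3 in more than one place, so its number cannot be assigned to any single change.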